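The compounds below may be only part of what the source reports. "The series", "measured", "known", "first", "only" and "open" are said of these compounds alone.

Measured so far in an assay on BaF3 cells for inhibition of thrombopoietin receptor (Homo sapiens); a higher number here means that more compound is needed for the effect, a lower number that less compound is needed:
compound 1 `CC1=NN(c2ccc(C)c(C)c2)C(=O)/C1=C(/C)NNC(=O)N1CCc2cc(C(=O)O)ccc21` gives 42 nM
compound 2 `CC1=NN(c2ccc(C)c(C)c2)C(=O)/C1=C(/C)NNC(=S)N1CCc2cc(C(=O)N3CCOCC3)ccc21` gives 31 nM
compound 3 `CC1=NN(c2ccc(C)c(C)c2)C(=O)/C1=C(/C)NNC(=S)N1CCCc2cc(C(=O)O)ccc21` gives 64 nM

Compound 2 has the lowest of the three numbers. Its nearest neighbour is compound 1, whose number is higher only within the scatter, so no order between compound 1 and compound 2 can be claimed. Compound 3 lies further off, and the gap from compound 2 to compound 3 is beyond the scatter. Among the compounds with values here, the three compounds differ from one another in more than one place, so no single-point step is available among them.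

Compound 4 `CCNC(=O)c1ccc2c(c1)CCN2C(=S)NN/C(C)=C1\C(=O)N(c2ccc(C)c(C)c2)N=C1C` has not been measured in this assay. It differs from compound 2 in one place: ethylamino in place of morpholin-4-yl on a carbonyl carbon. Within the data shown here, no measured pair isolates this change. Compound 1, which carries a carboxylic acid rather than the amide at that carbonyl carbon, gives 42 nM, close to compound 2, which suggests that this part of the molecule tolerates variation. The step from compound 2 to compound 4 is therefore expected to be small, a 1.1-fold higher number from compound 2 to compound 4 (0.05 log units; within the scatter), with no change beyond the scatter in either direction. For compound 4 a value of 35 nM is expected, within a range from 15 nM to 85 nM.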

Compound 4, half-maximal effective concentration: 26 nM
Estimate against measurement, compound 4: 1.3-fold (0.13 log units) above; the range from low to high includes it.
By their numbers in this assay, from the lowest: compounds 4, 2, 1 and 3 (each within the scatter of the next, the first and the last beyond it).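

In this assay, within the data shown here, the replacement of morpholin-4-yl by ethylamino on a carbonyl carbon gives the first step that isolates one place, and it reads a 1.2-fold lower number from compound 2 to compound 4 (0.08 log units; within the scatter) for this change. The amide at this place can therefore lose its ring, going from 6 heavy atoms to 3 and gaining 1 hydrogen-bond donor, with no change beyond the scatter. Nothing on hand offers an explanation for this result.

Still open, on these data alone, is whether the same holds for a longer chain on the amide nitrogen, such as n-butylamino, or for a dimethylamino group, which has no amide hydrogen. The carboxylic acid at this carbonyl carbon appears here only together with changes elsewhere, so its own contribution cannot be read.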